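A few compounds are considered here, and "the series" means these few. Any claim that something is new, unique, unknown or untested is made for them only; others in the source may bear on it.

Measured compounds and their values:

Compound 1 `CC(C)(C)OC(=O)N1CCC(O[C@H]2CC[C@H](Oc3cnc(C#N)cn3)CC2)CC1`: in a functional assay on isolated protein for agonist activity at Glucose-dependent insulinotropic receptor (Homo sapiens), read by HTRF and cAMP accumulation (on this read-out higher numbers stand for larger maximal responses and lower numbers for smaller maximal responses), compound 1 gives 110%.
Compound 2 `CC(C)(C)OC(=O)N1CCC(O[C@H]2CC[C@H](Oc3ccc(S(C)(=O)=O)nn3)CC2)CC1`: in this assay compound 2 gives 97%.
Compound 3 `C[C@@H](CF)OC(=O)N1CCC(O[C@H]2CC[C@H](Oc3cnc(S(C)(=O)=O)cn3)CC2)CC1`: in this assay compound 3 gives 105%.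

Compound 3 stands second highest of the three numbers; its value lies within the scatter of compound 1 and likewise within the scatter of compound 2, so no order among these three can be claimed. Going by the values given here, the one step that is known, a number 13 percentage points lower from compound 1 to compound 2 (beyond the scatter), concerns the group on the oxygen on a saturated carbon and not the amine nitrogen.

Compound 4 `CC(F)Cc1nc(CN2CCC(O[C@H]3CC[C@H](Oc4cnc(S(C)(=O)=O)cn4)CC3)CC2)no1` differs from compound 3 in this way: a group of 10 heavy atoms (6 carbon, 2 nitrogen, 1 oxygen, 1 fluorine; one five-membered aromatic ring with 3 hetero atoms) in place of a group of 7 heavy atoms (4 carbon, 2 oxygen, 1 fluorine; no ring), on an amine nitrogen in a ring. Among the compounds with values here, no measured step covers a change at this position; the only known step is modest, and all three measured values sit within a narrow band. Compound 4 is therefore expected to give 100% in this assay, with a range from 80% to 115%, which means an expected step of a number 5 percentage points lower from compound 3 to compound 4 (within the scatter), not beyond the scatter.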

Compound 4, largest response reached (Emax), in percent of the reference or control that the assay uses: 97%
Compound 4: middle estimate off by 3 percentage points, on the high side; low and high end bracket the measured number.
By their numbers in this assay, from the lowest: compounds 2, 4, 3 and 1 (each within the scatter of the next, the first and the last beyond it).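

Going by these compounds alone, this is the first measured change on the amine nitrogen in a ring: in this assay, putting (5-(2-fluoropropyl)-1,2,4-oxadiazol-3-yl)methyl in place of the ringless group gives a number 8 percentage points lower from compound 3 to compound 4 (within the scatter). The maximal response at this position therefore does not depend on keeping the ringless group, since a group with a five-membered aromatic ring serves within the scatter. Nothing available explains this result. Going by these compounds, whether a plain methyl or a chain ending in a carboxylic acid on this nitrogen would give a similar response remains open, as does the part played by the fluorine of the 2-fluoropropyl chain.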